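A few compounds are considered here, and "the series" means these few. Any claim that something is new, unique, unknown or untested is made for them only; others in the source may bear on it.

Compound 1 `COc1ccc(-c2cnc(NC(=O)C3CCNCC3)n2C)cc1`: > 100000 nM
Compound 2 `Cn1c(-c2ccccc2Cl)cnc1NC(=O)c1ncc[nH]1`: > 50000 nM
Compound 3 `COc1cccc(-c2cnc(NC(=O)c3ccc(F)cc3)n2C)c1`: > 100000 nM

All three results come from a toxicity assay on THP-1 cells (Homo sapiens) for inhibition (on this read-out higher numbers stand for lower toxicity in this test and lower numbers for higher toxicity in this test), and each one is a limit of the assay rather than a number. In this assay compound 3 gives > 100000 nM, which is such a limit. It therefore stands at the limit of > 100000 nM in this assay, at which 2 of the 3 values shown sit.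

Compound 4 `Cn1c(-c2ccc(C#N)cc2)cnc1NC(=O)c1ccc(F)cc1` carries 4-cyanophenyl in place of 3-methoxyphenyl on an aromatic carbon. Among the measured compounds shown here, no measured pair shows the size of a change like this one. Starting from compound 3 at > 100000 nM, no step beyond the scatter is expected. The estimated change is a number no higher from compound 3 to compound 4 (the limit leaves the size open). For compound 4 the expected value is 100000 nM, with an estimated range from 30000 nM to 150000 nM.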

Compound 4, half-maximal cytotoxic concentration: > 50000 nM
Compound 4 was reported as a limit (the forecaster's own chance of this, stated with the estimate: 75%); the middle value is on the limit's open side.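

The results for compound 3 and compound 4 in this assay are both limits rather than numbers, and the step between them cannot be read. The compounds shown leave open whether 4-cyanophenyl in place of 3-methoxyphenyl changes toxicity at all.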